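A few compounds are considered here, and "the series" means these few. Any claim that something is new, unique, unknown or untested is made for them only; others in the source may bear on it.

Measured in a physicochemical assay for solubility (on this read-out lower numbers stand for lower solubility and higher numbers for higher solubility), so far:
- compound 1 `COc1ccc(-n2cnc3cnc(-c4ccc(F)cc4C)cc32)cc1OC` gives > 200000 nM as a limit of the assay, not a number
- compound 2 `COc1ccc(-n2cnc3cnc(-c4cc(F)ccc4C)cc32)cc1OC` gives 157000 nM as a number

Among the measured compounds shown here, compound 2 holds the only number, 157000 nM in this assay, so there is no numeric neighbour to rank it against. For compound 1 the record is the limit of > 200000 nM in this assay, at which 1 of the 2 values shown sits, and nothing more. For the measured compounds named here, the one measured step is an at least 1.2-fold lower number from compound 1 to compound 2 (0.10 log units; that floor lies within the scatter) and it stays within the scatter. That step leaves the methyl group in place, so it gives no direct size for the next change.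

Compound 3 `COc1ccc(-n2cnc3cnc(-c4cc(F)ccc4OC)cc32)cc1OC` carries methoxy in place of methyl on an aromatic carbon, ortho to a large group and para to a fluoro group. The counted difference reads methoxy in place of methyl on an aromatic carbon for this change.

Going by the values given here, no measured step covers this swap, so the expectation starts from compound 2 at 157000 nM and no shift beyond the scatter is expected in this assay for now. The expected step is a 1.0-fold lower number from compound 2 to compound 3 (0.02 log units; within the scatter) as an estimate only. Compound 3 is estimated at 150000 nM with an expected range from 70000 nM to 200000 nM in this read-out.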

Compound 3, solubility: 9000 nM
Beside the measured number, compound 3's estimate is 17-fold (1.22 log units) above it, outside the stated range (below it).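

In this assay, the earlier pair changed where the fluoro group sits while the methyl group stayed in place, and that step stayed within the scatter. The position ortho to a large group and para to a fluoro group now gives the first response beyond the scatter, with methoxy in place of methyl producing a 17-fold lower number from compound 2 to compound 3 (1.24 log units; beyond the scatter) and so showing that this read-out is sensitive to the change at this carbon. The wider comparison, in which the fluoro group also differs in place, gives an at least 22-fold lower number from compound 1 to compound 3 (1.34 log units; beyond the scatter) as a floor on the size of the step, and compound 1 is recorded only as a limit of the assay: the limit of > 200000 nM in this assay, at which 1 of the 3 values shown sits.

With a single methoxy compound, it stays open whether the same swap gives a step of this size when the fluoro group sits as it does in compound 1, and the compounds shown give no cause for the step. Ethoxy, hydroxyl or an amine on this same carbon would show whether the size of the step goes with the oxygen of methoxy or with the group as a whole.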